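Pyridin-3-yl to 1-methyl-1H-pyrazol-5-yl on the sulfonamide nitrogen

A few compounds are considered here, and "the series" means these few. Any claim that something is new, unique, unknown or untested is made for them only; others in the source may bear on it.

Three measured compounds share a core in which a sulfonamide nitrogen also carries a saturated chain ending in an amide. Compound 1 `CCc1ccccc1N(CC(=O)NCc1cccc(OC)c1)S(=O)(=O)c1ccc(C)cc1` and compound 2 `CCc1ccccc1N(CC(=O)NCc1ccc(C(F)(F)F)cc1)S(=O)(=O)c1ccc(C)cc1` differ only on the amide side. In a functional assay on CHO-K1 cells for antagonist activity at prostaglandin E2 receptor EP1 subtype (Homo sapiens), read by FLIPR and calcium flux (on this read-out higher numbers stand for weaker inhibition and lower numbers for stronger inhibition), compound 1 gives 138 nM, and compound 2 gives 209 nM. The step of a 1.5-fold higher number from compound 1 to compound 2 (0.18 log units; within the scatter) therefore lies within the scatter of repeated measurements. Compound 3 `Cc1ccc(S(=O)(=O)N(CC(=O)NCc2ccc(Cl)cc2)c2cccnc2)cc1` carries pyridin-3-yl on the sulfonamide nitrogen. For compound 3 this assay reports only a limit, < 1450 nM, as noted in the limit of < 1450 nM in this assay, at which 1 of the 3 values shown sits. Compound 4 `Cc1ccc(S(=O)(=O)N(CC(=O)NCc2ccc(Cl)cc2)c2ccnn2C)cc1` differs from compound 3 in one place: 1-methyl-1H-pyrazol-5-yl in place of pyridin-3-yl on a sulfonamide nitrogen. Among the compounds with values here, no measured step touches the sulfonamide nitrogen; the only measured step, a 1.5-fold higher number from compound 1 to compound 2 (0.18 log units; within the scatter), sits on the amide side and was within the scatter, so it gives no guide to the size or direction of this change. Since the starting point is only a limit, the expected step that the limit leaves unreadable from compound 3 to compound 4 carries wide uncertainty and is set close to no change. Compound 4 in this assay is estimated at 1000 nM, with a range from 200 nM to 5000 nM.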

Compound 4, inhibition constant: 589 nM
Estimate against measurement, compound 4: 1.7-fold (0.23 log units) above, within the range that was stated.
By their numbers in this assay, from the lowest: compounds 1 and 2 (each within the scatter of the next); then compound 4.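

No size can be read for the change from compound 3 to compound 4, because the value of compound 3 is a limit and not a number: the limit of < 1450 nM in this assay, at which 1 of the 4 values shown sits.

In this assay the compounds shown leave open whether 1-methyl-1H-pyrazol-5-yl on the sulfonamide nitrogen gives stronger or weaker inhibition than pyridin-3-yl, or about the same.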